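Bromomethyl in Place of Methoxymethyl on a Limited Baseline

This account rests on a few compounds, and the source may have more. Where it says the series, first, only, none or still open, it means among the compounds named here.

Compound 3, `CCc1cccc2c(OC)c(-c3occ(C)c3COC)ccc12`, is one of three measured compounds on a shared core. In a functional assay on DU-145 cells (Homo sapiens) for cytotoxicity, read by MTT assay, with a stated time of 72 h (on this read-out higher numbers stand for an effect only at larger amounts of compound and lower numbers for an effect already at smaller amounts), compound 3 returns only a limit, > 10 ug/mL. Compound 1, `CCOC(=O)c1c(C)coc1-c1ccc2c(CC)cccc2c1OC`, is the only one of the three with a number and gives 2.2 ug/mL in this assay. Compound 2, `CCc1cccc2c(OC)c(-c3occ(C)c3C(=O)NC)ccc12`, also stops at a limit, > 10 ug/mL. Two steps lead away from compound 1: an at least 4.5-fold higher number from compound 1 to compound 2 (0.65 log units; beyond the scatter) and an at least 4.5-fold higher number from compound 1 to compound 3 (0.65 log units; beyond the scatter). The third step is a step that the two limits leave unreadable from compound 2 to compound 3 because of the limit of > 10 ug/mL in this assay, at which 2 of the 3 values shown sit.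

Compound 4, `CCc1cccc2c(OC)c(-c3occ(C)c3CBr)ccc12`, differs from compound 3 in one place: bromo in place of methoxy on a saturated chain carbon bound to an aromatic carbon. Among the measured compounds shown here, of the measured steps, only an at least 4.5-fold higher number from compound 1 to compound 3 (0.65 log units; beyond the scatter) touches this saturated chain carbon, and there the exchange was ethoxycarbonyl for methoxymethyl rather than methoxy for bromo, so no measured step reports the present change directly. The baseline of compound 3 is a limit, so only a move toward smaller amounts of compound could be read as a step at all. On this footing the expected step is an at least 2.5-fold lower number from compound 3 to compound 4 (0.39 log units; beyond the scatter). The value expected for compound 4 in this assay is 4 ug/mL, with a range from 0.8 ug/mL to 12 ug/mL.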

Compound 4, concentration for half-maximal effect: > 10 ug/mL
Compound 4 gave a limit, no number (the forecaster's own chance of this, stated with the estimate: 30%); middle value at least 2.5-fold (0.39 log units) from the limit.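

In this assay compound 4 gives > 10 ug/mL, which is a limit of the assay and not a number. Exchanging ethoxycarbonyl for bromomethyl on this aromatic carbon gives an at least 4.5-fold higher number from compound 1 to compound 4 (0.65 log units; beyond the scatter), making it the third replacement of ethoxycarbonyl shown to move the same way, after methylcarbamoyl and methoxymethyl, with no compound among those shown going against this. The change from methoxy to bromo on the saturated chain carbon adds no readable information, however, and neither the step to compound 4 from compound 3 nor the one from compound 2 can be read, because both ends of each sit at the same limit: the limit of > 10 ug/mL in this assay, at which 3 of the 4 values shown sit.

As far as these compounds go, what remains open is how far compound 2, compound 3 and compound 4 lie beyond the limit, and so whether bromo and methoxy differ at all on this saturated chain carbon. From the compounds shown here alone, it also remains open how a carboxylic acid in place of ethoxycarbonyl, a longer chain in place of its ethoxy, or an amine in place of the bromo would read on this assay, and whether any of them would return a number.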